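Swapping Furan-2-yl for Methyl on a Shared Core

The compounds below may be only part of what the source reports. "The series", "measured", "known", "first", "only" and "open" are said of these compounds alone.

Of the compounds shown here, three on a shared core have been tested in a functional assay on SH-SY5Y cells (Homo sapiens) for cytotoxicity, with a stated time of 24 h; a lower number here means a stronger inhibitor, a higher number a weaker inhibitor. Compound 1 `Cc1cc2c(c(=O)o1)C=C(c1ccccc1)C(CC(C)C)O2` gives 93000 nM there. Compound 2 `CC1=Cc2c(cc(C)oc2=O)OC1c1ccco1` gives 49000 nM in this assay, the lowest of the two numbers, yet its gap to compound 1 lies within the scatter, so the two read as alike. Compound 3 `CCC1C=Cc2c(cc(C)oc2=O)O1` in this assay reaches only a limit of > 200000 nM, not a number. the limit of > 200000 nM in this assay, at which 1 of the 3 values shown sits, marks where that value sits.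

Compound 4 `CC1=Cc2c(cc(C)oc2=O)OC1C` differs from compound 2 by methyl in place of furan-2-yl on a saturated ring carbon. Among the compounds with values here, no measured pair of compounds traces this exact change, so the expectation rests on the values shown. Compound 3, which carries a small alkyl group rather than an aromatic ring on its saturated ring, reaches only a limit, and that points toward weaker inhibition when the furan-2-yl is given up. Compound 4 is therefore expected to give about 150000 nM in this assay, between 50000 nM and 400000 nM. The step of a 3.1-fold higher number from compound 2 to compound 4 (0.49 log units; beyond the scatter) is expected to weaken inhibition beyond the scatter, with a fair chance that only a limit is reported.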

Compound 4, half-maximal inhibitory concentration: 200000 nM
For compound 4 the middle estimate is 1.3-fold (0.12 log units) below the measured one, and the stated range covers the measured number.
By their numbers in this assay, from the lowest: compounds 2 and 1 (each within the scatter of the next); then compound 4.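

Within the data shown here, replacing furan-2-yl with methyl on this saturated ring carbon, next to the ring oxygen, gives the first change in a single place that can be read in this assay: a 4.1-fold higher number from compound 2 to compound 4 (0.61 log units; beyond the scatter). Among these compounds, at this position, then, the furan-2-yl compound carries the lower number and the methyl compound the higher one, something the earlier compounds could only hint at, since none of them differed from another in one place alone. Compound 3 stands in this assay only as a limit, not a number: the limit of > 200000 nM in this assay, at which 1 of the 4 values shown sits.

As far as these compounds go, it remains open whether another ring, such as thiophen-2-yl or pyridin-2-yl, or a longer chain such as n-butyl, would keep the lower number at this carbon. A single step also cannot show whether the same change would act alike with other groups elsewhere on the shared core.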